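The compounds below may be only part of what the source reports. "The series", "measured", "known", "first", "only" and "open" are said of these compounds alone.

Working notes on the series. The shared core of compound 1 `COc1cc2c(cc1OC)C(CC(=O)O)CC2` carries an acid, which in a functional assay on the whole organism (strain Wistar) for inhibition, with Rattus norvegicus as the target, read by paw edema, with stated times of 60 min and 4 h, at a dose of 100 mg/kg by the oral route (on this read-out higher numbers stand for more inhibition at the one dose given (going by the name of the read-out) and lower numbers for less inhibition), gives compound 1 23.9%. Compound 2 `CCN(CC)C(=O)CC1CCc2cc(OC)c(OC)cc21` gives 37.5% in this assay, and compound 3 `CCCCNC(=O)CC1CCc2cc(OC)c(OC)cc21` gives 25% in this assay. Compound 3 thus stands second of the three; its gap to compound 1 lies within the scatter, while the step of a number 12.5 percentage points lower from compound 2 to compound 3 (beyond the scatter) is beyond it, as is a number 13.6 percentage points higher from compound 1 to compound 2 (beyond the scatter).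

The next step, to compound 4 `COc1cc2c(cc1OC)C(CC(=O)N1CCOCC1)CC2`, is morpholin-4-yl in place of butylamino on a carbonyl carbon. Among the compounds with values here, the one measured step that bears on it directly is the exchange of one amine for another on the same carbonyl carbon, a number 12.5 percentage points lower from compound 2 to compound 3 (beyond the scatter), which was modest. That change ran toward a lower number; the present one moves from butylamino to a ring amine, and a modest rise, or no step beyond the scatter, seems the likelier outcome, with the step from compound 3 to compound 4 expected as a number 7 percentage points higher from compound 3 to compound 4 (within the scatter). In this assay compound 4 is therefore estimated at 32%, with a range from 20% to 45%.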

Compound 4, a percentage reported as inhibition, in the whole organism at one dose (the size of the read-out at that dose, not a potency): 13.3%
Beside the measured number, compound 4's estimate is 18.7 percentage points above it; the whole stated range lies above it.
By their numbers in this assay, from the lowest: compound 4; then compounds 1 and 3 (each within the scatter of the next); then compound 2.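

In this assay the group on the carbonyl carbon can lower the number as well as raise it (in a number 10.6 percentage points lower from compound 1 to compound 4 (beyond the scatter)), whereas among the earlier amides diethylamino gave a rise and butylamino no step beyond the scatter. Lacking the amide hydrogen does not by itself go with the higher number: morpholin-4-yl and diethylamino both lack it, yet the two amides stand well apart (in a number 24.2 percentage points lower from compound 2 to compound 4 (beyond the scatter)). The ring amine also falls below the secondary amide (in a number 11.7 percentage points lower from compound 3 to compound 4 (beyond the scatter)), which leaves compound 4 the lowest of the four.

Going by these compounds, whether the fall follows the ring or its oxygen stays open, and piperidin-1-yl, the same ring with a carbon in place of that oxygen, would separate the two. Nothing at hand gives a reason for these steps.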